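Swapping Oxygen for Sulfur in the Side Chain

The source may hold more compounds than are shown below. What is called first, only, known or untested is meant among the compounds shown, and "the series" means these compounds.

Compound 1 `CCCOCCn1c(N2CCN(C)CC2)nc2ccccc21` carries a propoxy group on the side chain attached to its core. In a functional assay on ileum for inhibition of histamine H1 receptor (Cavia porcellus) (a lower number here means a stronger inhibitor, a higher number a weaker inhibitor), compound 1 gives 20 nM. For the measured compounds named here, of the two numbers recorded, that of compound 1 stands at the top, yet the only other compound, compound 2 `CCCOCCn1c(N2CCCN(C)CC2)nc2ccccc21`, gives 16 nM in this assay, and the two values lie within the scatter of each other, so they show no difference between the two compounds.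

Compound 3 `CCSCCCn1c(N2CCN(C)CC2)nc2ccccc21` has not yet been measured. It differs from compound 1 in one place: (ethylsulfanyl)methyl in place of propoxy on a saturated chain carbon, two bonds along the chain from an aromatic nitrogen. The group that leaves and the group that enters match each other in the counts given, and only the kind of one atom changes. Going by the values given here, no step between measured compounds covers a change of this sort, so there is no measured step to lean on.

The step from compound 1 to compound 3 is expected to be no change at the digits printed from compound 1 to compound 3 (within the scatter), that is, none beyond the scatter. Compound 3 is therefore expected to give about 20 nM in this assay, within a range from 8 nM to 50 nM.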

Compound 3, half-maximal inhibitory concentration: 530 nM
Compound 3: middle estimate off by 27-fold (1.42 log units), on the low side; measured number outside the range, above it.
By their numbers in this assay, from the lowest: compounds 2 and 1 (each within the scatter of the next); then compound 3.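

In this assay this position proves sensitive to the change: (ethylsulfanyl)methyl in place of propoxy gives a 27-fold higher number from compound 1 to compound 3 (1.42 log units; beyond the scatter) and makes compound 3 a clearly weaker inhibitor than compound 1. The group that leaves and the group that enters match in heavy atoms, hydrogen-bond donors and hydrogen-bond acceptors, so at this place, on a saturated chain carbon, two bonds along the chain from an aromatic nitrogen, those counts alone do not settle the outcome. No measurement at hand bears on why the number rises so far.

The names 2-propoxyethyl and 3-(ethylsulfanyl)propyl show that more than the kind of one atom differs: sulfur replaces oxygen, while the ethyl and propyl parts of the chain trade places, and this single step cannot tell the two changes apart. A 2-(propylsulfanyl)ethyl chain, which swaps only the oxygen for sulfur, and a 3-ethoxypropyl chain, which keeps the oxygen but takes the chain arrangement of compound 3, would each separate the two on the same core.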